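Compound 3 to compound 4: larger group on the carbonyl

The compounds below may be only part of what the source reports. "The series", "measured", "known", "first", "only" and "open" are said of these compounds alone.

In an ADME assay on L02 cells (Homo sapiens) for cytotoxicity, read by MTT assay, with a stated time of 48 h (on this read-out higher numbers stand for weaker inhibition and lower numbers for stronger inhibition), compound 1 `CCOC(=O)CN(C)C(=O)c1ccc(C(CC)(CC)c2ccc(OCC(O)C(C)(C)C)c(C)c2)n1CC` gives 10100 nM, compound 2 `C#CC(C)OC(=O)c1ccc(C(CC)(CC)c2ccc(OCC(O)C(C)(C)C)c(C)c2)n1CC` gives 23700 nM and compound 3 `CCn1c(C(=O)N(C)CC(=O)O)ccc1C(CC)(CC)c1ccc(OCC(O)C(C)(C)C)c(C)c1` gives 32600 nM. Compound 3 is not separated from compound 2, with a 1.4-fold higher number from compound 2 to compound 3 (0.14 log units; within the scatter) lying within the scatter. It stands clear of compound 1 only, with a 3.2-fold higher number from compound 1 to compound 3 (0.51 log units; beyond the scatter).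

The change to compound 4 `CCn1c(C(=O)Oc2ccc(CCO)cc2)ccc1C(CC)(CC)c1ccc(OCC(O)C(C)(C)C)c(C)c1` is a group of 10 heavy atoms (8 carbon, 2 oxygen; one six-membered aromatic ring of carbon only) in place of a group of 6 heavy atoms (3 carbon, 1 nitrogen, 2 oxygen; no ring), on a carbonyl carbon. Among the measured compounds shown here, the entering group holds one six-membered aromatic ring of carbon only, and no group on that carbonyl carbon in the measured compounds has a ring, so the data offer no direct precedent.

The nearest guide is what other exchanges on this carbonyl carbon have done in this assay. The change from compound 1 to compound 2 gave a modest 2.3-fold higher number from compound 1 to compound 2 (0.37 log units; beyond the scatter), and the exchange from compound 2 to compound 3 stayed within the scatter. All three values lie in a narrow band, and compound 3 sits on its upper side alongside compound 2. A modest move to a lower number is therefore expected, estimated as a 2.0-fold lower number from compound 3 to compound 4 (0.31 log units; beyond the scatter). The estimate for compound 4 is 16000 nM, with an expected range of 6500 nM to 38000 nM.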

Compound 4, half-maximal inhibitory concentration: 22700 nM
Compound 4: middle estimate off by 1.4-fold (0.15 log units), on the low side, within the range that was stated.
By their numbers in this assay, from the lowest: compound 1; then compounds 4, 2 and 3 (each within the scatter of the next).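

In this assay, among the compounds shown here, the first group with a ring on this carbonyl carbon does not separate from the ring-free (carboxymethyl)(methyl)amino group (a 1.4-fold lower number from compound 3 to compound 4 (0.16 log units; within the scatter)), nor does 4-(2-hydroxyethyl)phenyl separate from 1-methylprop-2-yn-1-yl on the same ester oxygen (a 1.0-fold lower number from compound 2 to compound 4 (0.02 log units; within the scatter)). Compounds 2, 3 and 4 therefore form one group within the scatter despite their different groups on this carbon, and adding a ring and more heavy atoms gives no resolved change among them, while compound 1 remains apart (a 2.2-fold higher number from compound 1 to compound 4 (0.35 log units; beyond the scatter)). No supporting data bear on why compound 1 alone stands apart.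

Open, going by these compounds, is whether a plain phenyl, or a ring carrying an amine in place of the 2-hydroxyethyl chain, would stay with compounds 2, 3 and 4 or move towards compound 1. Also open, on these data alone, is whether a longer chain on the ester of the (ethoxycarbonyl)methyl group would keep the lower number of compound 1 or lose it.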